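Trifluoromethyl for amino on the ketone-side aryl ring

A few compounds are considered here, and "the series" means these few. Any claim that something is new, unique, unknown or untested is made for them only; others in the source may bear on it.

Three compounds of this series share one core and differ only in the aryl group on the carbonyl carbon. Compound 1 `CCCCOc1ccc(C(=O)/C=C/c2c(/C=C/c3ccc(OC)cc3)cc(OC)cc2OC)cc1` gives 12.9 ug/mL in a functional assay on HepG2 cells (Homo sapiens) for antiproliferative activity, read by MTT assay, with a stated time of 48 h; on this read-out higher numbers stand for weaker inhibition and lower numbers for stronger inhibition. Compound 2 `COc1ccc(/C=C/c2cc(OC)cc(OC)c2/C=C/C(=O)c2ccc(Cl)c(Cl)c2)cc1` gives 10.8 ug/mL in this assay, and compound 3 `COc1ccc(/C=C/c2cc(OC)cc(OC)c2/C=C/C(=O)c2ccc(N)cc2)cc1` gives 7.5 ug/mL. Compound 3 carries the lowest of the three numbers, but its gaps to the others are small: a 1.4-fold lower number from compound 2 to compound 3 (0.16 log units; within the scatter), and a 1.7-fold lower number from compound 1 to compound 3 (0.24 log units; within the scatter). The three measured compounds are thus not separated beyond the scatter.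

Compound 4 `COc1ccc(/C=C/c2cc(OC)cc(OC)c2/C=C/C(=O)c2ccc(C(F)(F)F)cc2)cc1` is the next member. It differs from compound 3 as follows: trifluoromethyl in place of amino on an aromatic carbon. Going by the values given here, the steps that bear on this change are those in which the group on the same aromatic carbon was exchanged, namely a 1.7-fold lower number from compound 1 to compound 3 (0.24 log units; within the scatter) and a 1.4-fold lower number from compound 2 to compound 3 (0.16 log units; within the scatter), both within the scatter, as is a 1.2-fold lower number from compound 1 to compound 2 (0.08 log units; within the scatter). Nothing among these compounds shows that a change on this ring moves the number beyond the scatter, so no step beyond the scatter is expected for compound 4; the expected step is a 1.3-fold higher number from compound 3 to compound 4 (0.12 log units; within the scatter). Compound 4 is estimated at 10 ug/mL in this assay, in the range 4.5 ug/mL to 22 ug/mL.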

Compound 4, half-maximal inhibitory concentration: 18.7 ug/mL
Beside the measured number, compound 4's estimate is 1.9-fold (0.27 log units) below it; measured number inside the range.
By their numbers in this assay, from the lowest: compounds 3, 2, 1 and 4 (each within the scatter of the next, the first and the last beyond it).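

In this assay, going by these compounds alone, the exchange of amino for trifluoromethyl on this aromatic carbon gives the first step beyond the scatter (a 2.5-fold higher number from compound 3 to compound 4 (0.40 log units; beyond the scatter)), though a modest one. Compound 4 is not separated from the other two compounds, with a 1.7-fold higher number from compound 2 to compound 4 (0.24 log units; within the scatter) and a 1.4-fold higher number from compound 1 to compound 4 (0.16 log units; within the scatter) both within the scatter, so the aryl group on the carbonyl carbon has moved the number beyond the scatter in this single pair only. No measurement bears on what lies behind this step.

On these data alone, whether a dimethylamino, hydroxyl or carboxylic acid group on this carbon would stay near compound 3 or near compound 4 remains open. Also open, as far as these compounds go, is whether the step from amino to trifluoromethyl would hold on a different aromatic carbon of this ring.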